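Anilino to piperidin-1-yl on the shared core

This account rests on a few compounds, and the source may have more. Where it says the series, first, only, none or still open, it means among the compounds named here.

Measured in a functional assay on MGC-803 cells (Homo sapiens) for inhibition, read by sulforhodamine B assay; a higher number here means a weaker inhibitor, a lower number a stronger inhibitor:
- compound 1 `O=C1C(Nc2ccccc2)=CC(=O)c2c1nc1n2[C@H]2OC[C@@H](O)[C@H]2OC1`: 1830 nM
- compound 2 `O=C1C=C(Nc2ccccc2F)C(=O)c2c1nc1n2[C@H]2OC[C@@H](O)[C@H]2OC1`: 2080 nM
- compound 3 `CCc1ccc(NC2=CC(=O)c3nc4n(c3C2=O)[C@H]2OC[C@@H](O)[C@H]2OC4)cc1`: 1290 nM

Compound 1, at 1830 nM, lies within the scatter of both compound 2 and compound 3, so the three values form one flat group with no order among them.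

The next compound to be read is compound 4 `O=C1C(N2CCCCC2)=CC(=O)c2c1nc1n2[C@H]2OC[C@@H](O)[C@H]2OC1`. It keeps the core of compound 1 and puts piperidin-1-yl in place of anilino on a double-bonded ring carbon. The entering ring is non-aromatic, and the measured compounds all carry an aromatic ring on that amine nitrogen.

Going by the values given here, only one measured step bears on this, and only indirectly. a 1.6-fold lower number from compound 2 to compound 3 (0.21 log units; within the scatter) exchanges 4-ethylphenyl for 2-fluorophenyl on an amine nitrogen, and it stays small. Among the compounds with values here, no measured step replaces the aromatic ring itself, so the data give no direction for this change in this assay. The change is larger than any measured so far, which calls for a wide range.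

The expected move, a 1.1-fold higher number from compound 1 to compound 4 (0.04 log units; within the scatter), is estimated to stay within the scatter. For compound 4 the estimated value is 2000 nM, with an expected range of 700 nM to 6000 nM.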

Compound 4, half-maximal inhibitory concentration: > 4000 nM
Compound 4: a limit, no number (the forecaster's own chance of this, stated with the estimate: 5%); middle value at least 2.0-fold (0.30 log units) from the limit.
By their numbers in this assay, from the lowest: compounds 3, 1 and 2 (each within the scatter of the next). At a limit, above all of these: compound 4.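

In this assay compound 4 gives > 4000 nM, which is a limit of the assay and not a number: the limit of > 4000 nM in this assay, at which 1 of the 4 values shown sits. Piperidin-1-yl in place of anilino on the double-bonded ring carbon gives an at least 2.1-fold higher number from compound 1 to compound 4 (0.33 log units; beyond the scatter), so this position shows a change beyond the scatter, which the exchange of one aromatic ring for another on the amine nitrogen did not show in a 1.6-fold lower number from compound 2 to compound 3 (0.21 log units; within the scatter). Going by these compounds alone, the aromatic ring on that nitrogen and the hydrogen-bond donor leave together in this single step, so the series so far tolerates different aryl groups on the amine nitrogen, but the one compound that has neither feature reads at the limit.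

The compounds shown leave open which of these two differences carries the step, and how far compound 4 really lies from compound 1 in this assay. A cyclohexylamino group, which keeps the amine hydrogen on a non-aromatic ring, and an N-methylanilino group, which keeps the aromatic ring without that hydrogen, would separate the two.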